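Aryl enone acids on HeLa cells: bromo to butyl

A few compounds are considered here, and "the series" means these few. Any claim that something is new, unique, unknown or untested is made for them only; others in the source may bear on it.

Measured so far:
- compound 1, `O=C(O)/C=C/C(=O)c1ccc(Br)cc1`: 18700 nM
- compound 2, `CCc1ccc(C(C)C)cc1C(=O)/C=C/C(=O)O`: 4890 nM

The read-out throughout is a functional assay on HeLa cells (Homo sapiens) for inhibition, read by MTT assay, with a stated time of 72 h; a lower number here means a stronger inhibitor, a higher number a weaker inhibitor. Compound 1 holds the highest number of the two measured compounds; compound 2 sits below it by a gap that lies beyond the usual scatter of the assay, so compound 2 is the stronger inhibitor of the pair. Among the measured compounds shown here, the two differ in more than one place on the aromatic ring, so no single step between them can be drawn.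

The next compound, compound 3, is `CCCCc1ccc(C(=O)/C=C/C(=O)O)cc1`. Against compound 1 the change is butyl in place of bromo on an aromatic carbon. Nothing else in the shared core moves.

For the measured compounds named here, no step between measured compounds is available to anchor this change. Compound 2, which carries only alkyl groups on the ring, gives the lower number, so an alkyl group in place of bromo is taken as more likely to lower the number than to raise it, though the expected shift from compound 1 to compound 3, a 2.1-fold lower number from compound 1 to compound 3 (0.32 log units; beyond the scatter), is modest and may not clear the scatter. Compound 3 is therefore expected at about 9000 nM in this assay, with a plausible range from 3500 nM to 25000 nM.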

Compound 3, half-maximal inhibitory concentration: 4780 nM
Estimate against measurement, compound 3: 1.9-fold (0.27 log units) above; low and high end bracket the measured number.
By their numbers in this assay, from the lowest: compounds 3 and 2 (each within the scatter of the next); then compound 1.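

In this assay, among the compounds shown here, butyl in place of bromo on an aromatic carbon, para to a group of 7 heavy atoms, gives the first step that can be read: a 3.9-fold lower number from compound 1 to compound 3 (0.59 log units; beyond the scatter). At this position, then, 4 heavy atoms (4 carbon) can replace 1 heavy atom (1 bromine) with a lower number rather than a higher one, and neither group brings a ring, a hydrogen-bond donor, a hydrogen-bond acceptor or a net charge into the comparison. Nothing at hand bears on why the number moves in this direction with this change.

This single step cannot separate what the butyl group adds from what the departure of bromo removes, so a plain hydrogen at this carbon would be the most informative reference point. It also gives no trend along a chain: a methyl or a longer chain such as hexyl, or a group of another kind such as an amine or a methoxy group, could each move the number either way at this position.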